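Thiazolyl for Hydrogen on a Ring Amine Side Chain

The source may report more compounds than this note shows. Statements on the series, on what has been measured and on what is new or still open speak of the compounds shown alone.

Compound 2 `CN1CCC[C@H](OCc2cc(Cl)cc(Cl)c2)[C@@H]1c1ccccc1` is the starting point. In an assay on isolated protein for activation of cGMP-dependent protein kinase 1 (Homo sapiens), read by ADP-Glo, with stated times of 120 min and 40 min (a lower number here means that less compound is needed, a higher number that more compound is needed for the effect), compound 2 gives > 200000 nM, which is a limit of the assay rather than a number. Its close relative compound 1 `Clc1cc(Cl)cc(CO[C@H]2CCCN(Cc3ncco3)[C@H]2c2ccccc2)c1` carries a 1,3-oxazol-2-yl group where compound 2 carries hydrogen. In this assay compound 1 gives > 200000 nM, again a limit and not a number. The step that the two limits leave unreadable from compound 1 to compound 2 therefore cannot be read in size. The unmeasured compound 3 `Clc1cc(Cl)cc(CO[C@H]2CCCN(Cc3nccs3)[C@H]2c2ccccc2)c1` is reached from compound 2 by 1,3-thiazol-2-yl in place of hydrogen on a saturated chain carbon bound to an amine nitrogen in a ring. Among the measured compounds shown here, the only measured step that bears on this change is the one between compound 1 and compound 2, and it offers no usable size because of the limit of > 200000 nM in this assay, at which 2 of the 2 values shown sit. For compound 3 the expectation is that this assay will once more stop at its limit, so the expected step that the limit leaves unreadable from compound 2 to compound 3 is none beyond the scatter. Compound 3 is expected to give 300000 nM, within 100000 nM to 1000000 nM.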

Compound 3, half-maximal effective concentration: > 200000 nM
Compound 3 was reported as a limit (the forecaster's own chance of this, stated with the estimate: 85%); the middle value does not contradict the limit.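

In this assay, among the compounds shown here, compound 1, compound 2 and compound 3 all stop at a limit of the assay, so no step among them can be read in size: the limit of > 200000 nM in this assay, at which 3 of the 3 values shown sit.

What these compounds leave open is whether any group at this place on the side chain gives a measurable value instead of a limit.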